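Adding an (isopropylamino)methyl Group to a Kinase Inhibitor Core

This account rests on a few compounds, and the source may have more. Where it says the series, first, only, none or still open, it means among the compounds named here.

Compound 1 has the structure `c1ccc2c(-c3cnc4[nH]nc(-c5nc6ccccc6[nH]5)c4c3)cncc2c1`; in an assay on isolated protein for inhibition of proto-oncogene tyrosine-protein kinase receptor Ret (Homo sapiens) (on this read-out higher numbers stand for weaker inhibition and lower numbers for stronger inhibition), compound 1 gives "not determined" (no result reported), so its position cannot be placed on this scale. Two related compounds give a sense of the range: compound 2 `COCc1cccc2[nH]c(-c3n[nH]c4ncc(-c5cccnc5)cc34)nc12` gives 1100 nM, and compound 3 `CN1CCN(c2ccc3[nH]c(-c4n[nH]c5ncc(-c6cncc7ccccc67)cc45)nc3c2)CC1` gives 1000 nM, two values that lie within the scatter of each other. Compound 4 `CC(C)NCc1cccc2[nH]c(-c3n[nH]c4ncc(-c5cncc6ccccc56)cc34)nc12` differs from compound 1 by (isopropylamino)methyl in place of hydrogen on an aromatic carbon. For the measured compounds named here, with no measured step of this kind to draw on, the change is expected to move the result by no more than the scatter, in no particular direction, and compound 4 is expected to fall close to the two measured relatives. For compound 4 the estimate in this assay is 1000 nM, within the range 300 nM to 3500 nM.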

Compound 4, half-maximal inhibitory concentration: > 100000 nM
Compound 4 gave a limit, no number (the forecaster's own chance of this, stated with the estimate: 10%); middle value at least 100-fold (2.00 log units) from the limit.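

In this assay no step can be read between compound 1 and compound 4. Compound 4 gives > 100000 nM, which is a limit and not a number. As far as these compounds go, what swapping hydrogen for (isopropylamino)methyl does to the result on the core of compound 1 stays open.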